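This account rests on a few compounds, and the source may have more. Where it says the series, first, only, none or still open, it means among the compounds named here.

Working notes on the anilide series.

Compound 1 `Cc1cc(NC(=O)c2cccc(C(F)(F)F)c2)ccc1NS(=O)(=O)C(F)(F)F` in an ADME assay on HEK293 cells (Homo sapiens) for cytotoxicity, read by MTT assay, with a stated time of 48 h (on this read-out higher numbers stand for weaker inhibition and lower numbers for stronger inhibition), gives 131000 nM. Compound 2 `COc1cc(NC(=O)c2cccc(C(F)(F)F)c2)ccc1NS(=O)(=O)C(F)(F)F` in this assay returns only a limit, > 250000 nM. Going by the values given here, the one single-point step between measured compounds, an at least 1.9-fold higher number from compound 1 to compound 2 (0.28 log units; that floor lies within the scatter), therefore reaches no further than its floor and stays within the scatter. Compound 3 `CS(=O)(=O)Nc1ccc(NC(=O)c2cccc(C(F)(F)F)c2)cc1F` in this assay likewise returns only a limit, > 250000 nM. Taken together, two of the three values sit at the limit of > 250000 nM in this assay, at which 2 of the 3 values shown sit, so compound 3 stands at the upper edge of what this read-out resolves, with compound 1 the only compound carrying a number.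

Compound 4 `O=C(Nc1ccc(NS(=O)(=O)C(F)(F)F)c(F)c1)c1cccc(C(F)(F)F)c1` has not yet been measured in this assay. Its difference from compound 3 is trifluoromethyl in place of methyl on a sulfonyl sulfur. Among the compounds with values here, no measured step changes the sulfonyl substituent; the only measured step, an at least 1.9-fold higher number from compound 1 to compound 2 (0.28 log units; that floor lies within the scatter), alters a group on an aromatic carbon and bears on this change only indirectly. What can be said is that compound 1 and compound 2 both carry the (trifluoromethyl)sulfonyl group that enters in compound 4. Of these, compound 1 gives 131000 nM. Compound 2, in this assay, returns only a limit.

Compound 4 is therefore expected near the limit region, at 180000 nM, within 90000 nM to 360000 nM. The expected step of an at least 1.3-fold lower number from compound 3 to compound 4 (0.14 log units; that floor lies within the scatter) is accordingly none beyond the scatter.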

Compound 4, half-maximal inhibitory concentration: 152000 nM
For compound 4 the middle estimate is 1.2-fold (0.07 log units) above the measured one; the range from low to high includes it.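

In this assay, the sulfonyl sulfur carries its first measured change, and trifluoromethyl in place of methyl gives an at least 1.6-fold lower number from compound 3 to compound 4 (0.21 log units; that floor lies within the scatter), so this step reaches only its floor and stays within the scatter. Fluoro in place of methoxy on the aromatic carbon gives an at least 1.6-fold lower number from compound 2 to compound 4 (0.21 log units; that floor lies within the scatter), likewise a floor within the scatter, and both of these steps are read against a limit: the limit of > 250000 nM in this assay, at which 2 of the 4 values shown sit. Fluoro in place of methyl on that carbon gives a 1.2-fold higher number from compound 1 to compound 4 (0.06 log units; within the scatter), the first step in the series read between two numbers rather than against a limit, and it shows no difference beyond the scatter.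

The true size of the steps that start from the two limit values cannot be read from the compounds shown. As far as these compounds go, it also stays open whether an ethyl or a longer chain on the sulfonyl sulfur, or an amine or a carboxylic acid on the aromatic carbon, would move the read-out beyond the scatter.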